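Removing a Methyl from the Shared Core

This account rests on a few compounds, and the source may have more. Where it says the series, first, only, none or still open, it means among the compounds named here.

Measured compounds:
- Compound 1, `Cc1nc2cc(C(F)(F)F)ccc2n1-c1ccc(C(=O)NC2CC2)s1`: in an in vitro ADME assay on microsomes from liver (Mus musculus) for pharmacokinetics, read by LC-MS (a higher number here means faster removal of the compound, a lower number slower removal), compound 1 reaches the value > 72 mL/min/kg, which is a limit of the assay and not a number.
- Compound 2, `Cc1nc2c(Cl)cc(F)cc2n1-c1ccc(C(=O)NC2CC2)s1`: in this assay compound 2 gives 42 mL/min/kg.
- Compound 3, `O=C(NC1CC1)c1ccc(-n2cnc3c(Cl)cc(F)cc32)s1`: in this assay compound 3 reaches > 72 mL/min/kg, again a limit of the assay rather than a number.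

The three compounds share a core; how the core of compound 1 and the core of compound 2 differ is not broken down here. Between compound 2 and compound 3 the change is hydrogen in place of methyl on an aromatic carbon, and it raised the number by an at least 1.7-fold higher number from compound 2 to compound 3 (0.23 log units; that floor lies within the scatter). That step has only a floor, because of the limit of > 72 mL/min/kg in this assay, at which 2 of the 3 values shown sit.

Compound 4, `O=C(NC1CC1)c1ccc(-n2cnc3cc(C(F)(F)F)ccc32)s1`, is not yet measured. For the measured compounds named here, it is reached from compound 1 by hydrogen in place of methyl on an aromatic carbon, the same change as the one from compound 2 to compound 3, in the same kind of place. Going by the values given here, compound 1 already sits at the limit, and the one measured instance of this change moved the number toward faster removal, so compound 4 is expected to sit at or beyond that limit as well. The step from compound 1 to compound 4 in this assay is estimated at a step that the limit leaves unreadable from compound 1 to compound 4. For compound 4 the expected value in this assay is 90 mL/min/kg, with a range from 60 mL/min/kg to 150 mL/min/kg, and most likely the assay will report only a limit.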

Compound 4, clearance: > 72 mL/min/kg
Compound 4 ended at the assay's limit (the forecaster's own chance of this, stated with the estimate: 85%); the middle value is on the limit's open side.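

In this assay compound 4 gives > 72 mL/min/kg, which is a limit of the assay and not a number. No step from compound 1 to compound 4 can be read, because both compounds sit at a limit: the limit of > 72 mL/min/kg in this assay, at which 3 of the 4 values shown sit.

The compounds shown leave open whether hydrogen in place of methyl changes the clearance of compound 1 at all, and by how much, in this assay.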